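The source may report more compounds than this note shows. Statements on the series, on what has been measured and on what is new or still open speak of the compounds shown alone.

Measured in a functional assay on SK-MEL-28 cells (Homo sapiens) for inhibition; on this read-out higher numbers stand for weaker inhibition and lower numbers for stronger inhibition:
- compound 1 `COc1cc(/C=C\c2ccc3ccccc3c2)ccc1F`: 450 nM
- compound 2 `C(=C\c1ccco1)\c1ccc2ccccc2c1`: > 5000 nM (a limit of the assay, not a number)

Among the compounds with values here, compound 1 is the only one of the pair with a numerical value. Compound 2 gives only a limit, > 5000 nM, and is one of the compounds at the limit of > 5000 nM in this assay, at which 1 of the 2 values shown sits.

Compound 3 `C(=C\c1ccc2ccccc2c1)\c1ccoc1` has the same atoms as compound 2, joined differently: furan-3-yl in place of furan-2-yl on a double-bonded chain carbon bound to a double-bonded chain carbon. Within the data shown here, no measured step in this assay covers this exchange, so any expectation here is loose. A small shift towards stronger inhibition is expected, and the estimated change is an at least 1.6-fold lower number from compound 2 to compound 3 (0.22 log units; that floor lies within the scatter). Compound 3 may also end up reported only as a limit. For compound 3 the expected value is 3000 nM, with an estimated range of 800 nM to 10000 nM.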

Compound 3, half-maximal inhibitory concentration: > 5000 nM
Compound 3 gave a limit, no number; the forecaster's own chance of this, stated with the estimate: 45%; middle value at least 1.6-fold (0.22 log units) away from the limit.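

Compound 2 and compound 3 both give only a limit in this assay, so no step can be read between them: the limit of > 5000 nM in this assay, at which 2 of the 3 values shown sit.

Going by these compounds, whether furan-3-yl in place of furan-2-yl changes inhibition at all remains open.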